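Swapping Fluoro for Hydroxy on a Potent Antagonist

The source may report more compounds than this note shows. Statements on the series, on what has been measured and on what is new or still open speak of the compounds shown alone.

Of the compounds shown here, three have been tested in an in vitro functional assay on HEK285-7 cells for antagonist activity at prostaglandin D2 receptor 2 (Homo sapiens), read by BRET and beta-arrestin recruitment; on this read-out lower numbers stand for stronger inhibition and higher numbers for weaker inhibition. Compound 1, `Nc1nc(-c2ccc(Cl)cc2)c(CC(=O)O)s1`, gives > 100000 nM, which is a limit of the assay rather than a number. Compound 3, `COc1ccc(OC)c(-c2nc(C(c3ccccc3)c3ccccc3)sc2CC(=O)O)c1`, likewise gives > 100000 nM, again only a limit. Within the data shown here, compound 2, `O=C(O)Cc1sc(C(c2ccc(F)cc2)c2ccc(F)cc2)nc1-c1ccnc(F)c1`, gives 4.7 nM, the sole true number among the three and so the only starting point. Compound 4, `O=C(O)Cc1sc(C(c2ccc(F)cc2)c2ccc(F)cc2)nc1-c1ccnc(O)c1`, differs from compound 2 by hydroxy in place of fluoro on an aromatic carbon, so that 2-fluoropyridin-4-yl becomes 2-hydroxypyridin-4-yl. Among the measured compounds shown here, no measured pair shows a change of this kind, so the outcome is uncertain. A modest loss of potency is expected, a step of a 5.3-fold higher number from compound 2 to compound 4 (0.73 log units; beyond the scatter) probably beyond the scatter. Compound 4 is therefore estimated at 25 nM, within a range from 4 nM to 200 nM.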

Compound 4, half-maximal inhibitory concentration: 890 nM
Compound 4: middle estimate off by 36-fold (1.55 log units), on the low side; measured number outside the range, above it.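

Among these compounds, this is the first measured change on the 2-fluoropyridin-4-yl group. In this assay, hydroxy in place of fluoro brings a 190-fold higher number from compound 2 to compound 4 (2.28 log units; beyond the scatter) and so counts as a large loss of potency. A swap of 1 heavy atom for 1 heavy atom, on the aromatic carbon next to the ring nitrogen, is thus enough to matter greatly, though nothing shown explains the rise.

On these data alone, only fluoro and hydroxy are seen at this carbon, so it stays open whether a nitrile or a methyl group there would lie nearer compound 2 or compound 4.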